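This account rests on a few compounds, and the source may have more. Where it says the series, first, only, none or still open, it means among the compounds named here.

Measured compounds:
compound 1, `Cc1ccc(C2C(C#N)=C(N)N(c3ccc(S(N)(=O)=O)cc3)C3=C2CCCC3)cc1`, in a functional assay on Ehrlich cells (Mus musculus) for cytotoxicity, read by trypan blue exclusion, with a stated time of 2 h, tested at 50 ug/mL (a lower number here means a weaker effect, a higher number a stronger effect of the compound at the concentration tested), compound 1 gives 80%
compound 2, `N#CC1=C(N)N(c2ccc(S(N)(=O)=O)cc2)C2=C(CCCC2)C1c1ccc(Cl)cc1Cl`, in this assay compound 2 gives 50%

Compound 2 stands lowest of the two numbers in this assay; its nearest neighbour is compound 1, and the step of a number 30 percentage points lower from compound 1 to compound 2 (beyond the scatter) lies beyond the scatter. Compound 3, `N#CC1=C(N)N(c2ccc(S(N)(=O)=O)cc2)C2=C(CCCC2)C1c1ccc(Cl)c(Cl)c1`, has not yet been measured in this assay. It differs from compound 2 in one place: 3,4-dichlorophenyl in place of 2,4-dichlorophenyl on a saturated ring carbon. Among the measured compounds shown here, the single measured step, a number 30 percentage points lower from compound 1 to compound 2 (beyond the scatter), exchanged one aryl group for another and is only a loose guide here, since the change to compound 3 keeps the same atoms and moves only where one chlorine sits on the ring. For the measured compounds named here, with no step of this kind measured, the expected step of a number 5 percentage points higher from compound 2 to compound 3 (within the scatter) is small and may fall within the scatter. Compound 3 is therefore estimated at 55%, with a range from 35% to 75%.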

Compound 3, a percentage reported as activity, at one concentration (the size of the read-out at that concentration, not a potency): 50%
Estimate against measurement, compound 3: 5 percentage points above, within the range that was stated.
By their numbers in this assay, from the lowest: compounds 2 and 3 (each within the scatter of the next); then compound 1.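

In this assay, moving one chlorine around the aryl group on the saturated ring carbon gives a step that cannot be read as an effect: no change at the digits printed from compound 2 to compound 3 (within the scatter). The other new step, a number 30 percentage points lower from compound 1 to compound 3 (beyond the scatter), matches the earlier a number 30 percentage points lower from compound 1 to compound 2 (beyond the scatter), so both dichlorophenyl groups give a lower number than 4-methylphenyl at this position, and none of the three compounds goes against this. Nothing available gives a reason for these readings.

Going by these compounds, what remains open is whether a single chlorine, as in 4-chlorophenyl, would already give the number seen with two chlorines. On these data alone, it is also open where an unsubstituted phenyl, a 4-methoxyphenyl or a 4-ethylphenyl group would fall relative to 4-methylphenyl and the dichlorophenyl pair.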